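Two Inactive Tetrahydroisoquinoline Amines and a Pyridylmethyl Variant

The compounds below may be only part of what the source reports. "The series", "measured", "known", "first", "only" and "open" are said of these compounds alone.

Compound 1 `c1ccc2c(c1)CN[C@@H](CN(CCCCNCC1CCOCC1)[C@H]1CCCc3cccnc31)C2` is one of two measured compounds here. In a functional assay on cells for agonist activity at C-X-C chemokine receptor type 4 (Homo sapiens), read by fluorescence and calcium flux, with a stated time of 90 s (a higher number here means that more compound is needed for the effect, a lower number that less compound is needed), compound 1 gives only a limit, > 30000 nM. Compound 2 `FC1(F)CCC(NC/C=C/CN(C[C@H]2Cc3ccccc3CN2)[C@H]2CCCc3cccnc32)CC1` likewise reaches only a limit in this assay, > 30000 nM. Both measured values therefore sit at the same place, described by the limit of > 30000 nM in this assay, at which 2 of the 2 values shown sit. Compound 3 `C(=C/CN(C[C@H]1Cc2ccccc2CN1)[C@H]1CCCc2cccnc21)\CNCc1ccccn1` carries (pyridin-2-yl)methyl in place of 4,4-difluorocyclohexyl on an amine nitrogen. Within the data shown here, with no measured step available, no direction beyond the scatter is expected from a number no higher from compound 2 to compound 3 (the limit leaves the size open). Compound 3 is estimated at 30000 nM, within 10000 nM to 100000 nM.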

Compound 3, half-maximal effective concentration: > 30000 nM
Compound 3: only a limit was reported; the forecaster's own chance of this, stated with the estimate: 70%; the middle value lies on the limit itself.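

Compound 3 also gives only a limit, so the steps from compound 1 and compound 2 to compound 3 cannot be read: the limit of > 30000 nM in this assay, at which 3 of the 3 values shown sit. The compounds shown leave open how the three truly compare and whether any group on that amine nitrogen would give a measurable effect.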